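The source may hold more compounds than are shown below. What is called first, only, known or untested is meant among the compounds shown, and "the series" means these compounds.

Measured so far:
compound 1, `NCC(O)Cn1c(=O)n(C2OC(CO)[C@@H](O)[C@H]2O)c2nc(N)nc(O)c21` — 110% in a functional assay on the whole organism (B cells) with Mus musculus as the target; a higher number here means a larger maximal response, a lower number a smaller maximal response
compound 2, `C=CCn1c(=S)n([C@@H]2O[C@H](CO)[C@H]3OC(C)(C)O[C@H]32)c2nc(N)nc(O)c21` — 89%

Compound 1 stands highest of the two numbers measured; compound 2 sits a good deal lower, and that gap is beyond the usual scatter. The two differ in several places at once, so no single change can be read from them.

Compound 3, `CCCCn1c(=O)n(C2OC(CO)[C@@H](O)[C@H]2O)c2nc(N)nc(O)c21`, is not yet measured. Its change from compound 1 is propyl in place of 2-amino-1-hydroxyethyl on a saturated chain carbon bound to an aromatic nitrogen. The group that leaves carries the donors and acceptors of the side chain; what enters is a plain chain. Among the compounds with values here, no measured pair shows this kind of change, so the expectation rests on compound 1 alone. A moderate decrease is expected, of size a number 15 percentage points lower from compound 1 to compound 3 (beyond the scatter), somewhat beyond the scatter. For compound 3 the expected value in this assay is 95%, within a range from 75% to 115%.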

Compound 3, largest response reached (reported as maximal response), in percent of the reference or control that the assay uses: 86%
Estimate against measurement, compound 3: 9 percentage points above; the range from low to high includes it.
By their numbers in this assay, from the lowest: compounds 3 and 2 (each within the scatter of the next); then compound 1.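

In this assay, within the data shown here, propyl in place of 2-amino-1-hydroxyethyl, on a saturated chain carbon bound to an aromatic nitrogen, gives a number 24 percentage points lower from compound 1 to compound 3 (beyond the scatter) and is the first reading of a change in one place. The group at this position therefore affects the maximal response, yet compound 3 still reaches 86% with a plain chain carrying no hydrogen-bond donors or acceptors there. Nothing at hand explains the size of this step.

The amine and the hydroxyl leave together, so this step cannot divide the loss between them. In this assay, going by these compounds, it also stays open how a 3-hydroxypropyl chain, a 3-aminopropyl chain, a carboxylic acid or a longer chain such as hexyl would stand at this place.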